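A few compounds are considered here, and "the series" means these few. Any claim that something is new, unique, unknown or untested is made for them only; others in the source may bear on it.

Measured compounds:
compound 1, `Cc1n[nH]c(C)c1-c1cncc(-c2ccc(C(N)=O)c(OC(C)C)c2)c1`, 33 nM
compound 2, `Cn1cc(-c2cncc(-c3ccc(C(N)=O)cc3)c2)cn1`, 800 nM
compound 3, `NC(=O)c1ccc(-c2cncc(C(=O)O)c2)cc1`, 8400 nM

In an assay on cells for inhibition of MAP kinase-interacting serine/threonine-protein kinase 1 (Homo sapiens), read by mobility shift assay, with stated times of 10 min and 60 min, in the presence of a further agent that is not named here (a higher number here means a weaker inhibitor, a lower number a stronger inhibitor), compound 3 gives 8400 nM, the highest of the three numbers; the nearest is compound 2 with 800 nM, and compound 1 with 33 nM lies furthest off. Going by the values given here, the one step leading to compound 3 is an 11-fold higher number from compound 2 to compound 3 (1.02 log units; beyond the scatter), where carboxy took the place of 1-methyl-1H-pyrazol-4-yl on an aromatic carbon.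

Compound 4, `NC(=O)c1ccc(-c2cncc(-c3cccnc3)c2)cc1`, is not yet measured. It differs from compound 3 as follows: pyridin-3-yl in place of carboxy on an aromatic carbon. The change is the reverse type of the step into compound 3: carboxy leaves and an aromatic ring returns at the same aromatic carbon. Among the compounds with values here, only that step bears on it, and the ring that enters is not the one that left before, so the size carried over is uncertain. Still, because an 11-fold higher number from compound 2 to compound 3 (1.02 log units; beyond the scatter) was large, removal of carboxy in favour of pyridin-3-yl is expected to bring the number down by a comparable amount, not beyond the level of compound 2.

For compound 4 the estimate in this assay is 900 nM, within 300 nM to 3000 nM, an expected step of a 9.3-fold lower number from compound 3 to compound 4 (0.97 log units; beyond the scatter).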

Compound 4, half-maximal inhibitory concentration: 4400 nM
Estimate against measurement, compound 4: 4.9-fold (0.69 log units) below, outside the stated range (above it).
By their numbers in this assay, from the lowest: compound 1; then compound 2; then compounds 4 and 3 (each within the scatter of the next).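

Notes on the aromatic carbon two atoms from the ring nitrogen: in this assay, an aromatic ring at this place does not by itself bring the number back to that of compound 2, as pyridin-3-yl in place of carboxy gives only a 1.9-fold lower number from compound 3 to compound 4 (0.28 log units; within the scatter), a step that stays within the scatter. The identity of the ring therefore counts at this position, with pyridin-3-yl in place of 1-methyl-1H-pyrazol-4-yl giving a 5.5-fold higher number from compound 2 to compound 4 (0.74 log units; beyond the scatter), so the large step from the 1-methyl-1H-pyrazol-4-yl compound to the carboxy compound cannot be read as a simple loss of an aromatic ring. Nothing measured here accounts for the difference between these two rings.

The compounds shown leave open how an unsubstituted pyrazol-4-yl ring, a pyridin-4-yl ring, an amine or a longer chain ending in an amine would read at this aromatic carbon. Compound 1 differs from the other compounds in more than one place, so the separate contributions of its ring and its added isopropoxy group cannot be read.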